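The source may hold more compounds than are shown below. What is called first, only, known or untested is meant among the compounds shown, and "the series" means these compounds.

Working notes on the series, all read in a functional assay on HL-60 cells (Homo sapiens) for cytotoxicity, read by WST assay, with a stated time of 48 h; a higher number here means that more compound is needed for the effect, a lower number that less compound is needed. Compound 1 `O=C1OC[C@H](Cc2ccccc2O)[C@H]1Cc1ccc(Cl)c(Cl)c1` gives 33000 nM, compound 2 `Cc1ccccc1C[C@H]1COC(=O)[C@@H]1Cc1ccc(Cl)c(Cl)c1` gives 22000 nM, and compound 3 `O=C1OC[C@H](Cc2cccc(F)c2)[C@H]1Cc1ccc(Cl)c(Cl)c1` gives 14000 nM. Compound 3 is separated from compound 1 only, with a 2.4-fold lower number from compound 1 to compound 3 (0.37 log units; beyond the scatter). The remaining comparison is a 1.6-fold lower number from compound 2 to compound 3 (0.20 log units; within the scatter), so those two cannot be ordered.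

The next compound is compound 4 `O=C1OC[C@H](Cc2ccc(F)c(F)c2)[C@H]1Cc1ccc(Cl)c(Cl)c1`. The change is fluoro in place of hydrogen on an aromatic carbon, ortho to a fluoro group and para to a large group, taking 3-fluorophenyl to 3,4-difluorophenyl.

Within the data shown here, no measured step adds a fluoro group to a ring that already carries one, so the evidence is indirect. Among the measured compounds shown here, the steps that bear on it are those that alter the same aromatic ring. These are a 1.5-fold lower number from compound 1 to compound 2 (0.18 log units; within the scatter), a 1.6-fold lower number from compound 2 to compound 3 (0.20 log units; within the scatter) and a 2.4-fold lower number from compound 1 to compound 3 (0.37 log units; beyond the scatter). Even the last of these, which exchanges the whole substituted phenyl group, stays modest. A single added fluoro group is therefore expected to give no step beyond the scatter in this assay, with no firm direction. The expected step is a 1.2-fold lower number from compound 3 to compound 4 (0.07 log units; within the scatter).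

For compound 4 the estimated value is 12000 nM, with an expected range from 6000 nM to 24000 nM.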

Compound 4, half-maximal effective concentration: 25000 nM
For compound 4 the middle estimate is 2.1-fold (0.32 log units) below the measured one, outside the stated range (above it).
By their numbers in this assay, from the lowest: compounds 3, 2, 4 and 1 (each within the scatter of the next, the first and the last beyond it).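

In this assay, among these compounds, the first direct reading of a fluoro group entering at this place, ortho to a fluoro group and para to a large group, is a 1.8-fold higher number from compound 3 to compound 4 (0.25 log units; within the scatter); the step lies within the scatter, so neither an effect nor a direction can be assigned to this change. The 3,4-difluorophenyl group also cannot be separated from the other two ring patterns, with a 1.1-fold higher number from compound 2 to compound 4 (0.06 log units; within the scatter) and a 1.3-fold lower number from compound 1 to compound 4 (0.12 log units; within the scatter), so compound 4 adds no second separation to the single one already seen from compound 1 to compound 3. No measurement shown bears on the cause of these small steps.

Going by these compounds, whether a carboxylic acid or an aminomethyl group on this same aromatic carbon would give a step beyond the scatter remains open. Also open, on these data alone, is how the series responds when an amine or a methoxy group replaces a chloro group on the other aromatic ring, which stays the same in all four compounds.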